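The source may report more compounds than this note shows. Statements on the series, on what has been measured and on what is new or still open speak of the compounds shown alone.

Measured compounds in a functional assay on A549 cells (Homo sapiens) for cytotoxicity, read by sulforhodamine B assay; on this read-out lower numbers stand for stronger inhibition and higher numbers for weaker inhibition:
compound 1 `C=C1[C@@H](C/C=C2/C(=O)OC[C@H]2OC(C)=O)[C@]2(C)CC[C@@H](OC(C)=O)[C@@](C)(CO[Si](C)(C)C(C)(C)C)[C@H]2C[C@@H]1O`, 6850 nM
compound 2 `C=C1[C@@H](OC(C)=O)C[C@@H]2[C@](C)(CO[Si](C)(C)C(C)(C)C)[C@H](OC(C)=O)CC[C@@]2(C)[C@@H]1C[C@@H](Nc1ccccc1F)C1=CCOC1=O`, 3190 nM
compound 3 `C=C1[C@@H](OC(C)=O)C[C@@H]2[C@](C)(COC=O)[C@H](OC(C)=O)CC[C@@]2(C)[C@@H]1C[C@@H](Nc1ccc(Br)cc1)C1=CCOC1=O`, 15900 nM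

Compound 3 gives the highest of the three numbers in this assay. Compound 1 sits nearest, with a lower number, and the gap to it lies beyond the scatter. Compound 2 sits furthest, with a clearly lower number, also beyond the scatter. No pair among these three differs in only one place, so no single-change step is available as a guide.

Compound 4 `C=C1[C@@H](OC(C)=O)C[C@@H]2[C@](C)(COC=O)[C@H](OC(C)=O)CC[C@@]2(C)[C@@H]1C[C@@H](Nc1ccc(OC)c(OC)c1)C1=CCOC1=O` differs from compound 3 only at the amine nitrogen: 3,4-dimethoxyphenyl in place of 4-bromophenyl on an amine nitrogen. With no comparable change measured in this set, a small step in this assay is expected, if any, and most likely toward a somewhat lower number, though one that may remain within the scatter. The estimated step of a 1.4-fold lower number from compound 3 to compound 4 (0.16 log units; within the scatter) reflects that. Compound 4 is expected to give about 11000 nM, within a range from 4000 nM to 32000 nM.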

Compound 4, half-maximal inhibitory concentration: > 50000 nM
Compound 4: only a limit was reported (the forecaster's own chance of this, stated with the estimate: 10%); middle value at least 4.5-fold (0.65 log units) away from the limit.
By their numbers in this assay, from the lowest: compound 2; then compound 1; then compound 3. At a limit, above all of these: compound 4.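

Going by these compounds alone, this is the first single-place comparison, and it shows that the aryl group on the amine nitrogen is not a neutral position in this assay: 3,4-dimethoxyphenyl in place of 4-bromophenyl gives an at least 3.1-fold higher number from compound 3 to compound 4 (0.49 log units; beyond the scatter). Compound 4 reads only as a limit, > 50000 nM. The step therefore has a lower bound but no known size.

One pair cannot separate the departure of the bromine from the arrival of the two methoxy groups. Plain phenyl or 4-methoxyphenyl on the same nitrogen would bear on that question.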